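A few compounds are considered here, and "the series" means these few. Any claim that something is new, unique, unknown or untested is made for them only; others in the source may bear on it.

Compound 1 `COc1cc(F)cc(-c2ccc(C(=O)N(Cc3cccc(OCCCCCC(=O)O)c3)C(C)C)cc2)c1`, compound 2 `CC(C)N(Cc1cccc(OCCCCCC(=O)O)c1)C(=O)c1ccc(-c2cccc(Cl)c2)cc1` and compound 3 `CCOC(=O)CCCCCOc1cccc(CN(C(=O)c2ccc(-c3cccnc3)cc2)C(C)C)c1` share one core and differ in the aryl group attached to it and at the chain end. In an ADME assay on Raji cells (Homo sapiens) for cytotoxicity, read by CellTiter-Glo and resazurin assay, with a stated time of 72 h (on this read-out higher numbers stand for an effect only at larger amounts of compound and lower numbers for an effect already at smaller amounts), compound 1 gives no number but only the assay limit > 26000 nM. Compound 2 likewise reaches only a limit in this assay, > 21900 nM. Compound 3 too gives only a limit in this assay, > 26000 nM. Compound 3 thus stands at the limit of > 26000 nM in this assay, at which 2 of the 3 values shown sit, while the remaining value sits at the limit of > 21900 nM in this assay, at which 1 of the 3 values shown sits. Among the compounds with values here, the one step between measured compounds, a step that the two limits leave unreadable from compound 1 to compound 2, runs between two limits and gives no readable size.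

Compound 4 `CCOC(=O)CCCCCOc1cccc(CN(C(=O)c2ccc(-c3cc(OC)ccc3F)cc2)C(C)C)c1` differs from compound 3 by 2-fluoro-5-methoxyphenyl in place of pyridin-3-yl on an aromatic carbon. Within the data shown here, no measured step bears on this change with a readable size, since every value shown is a limit. The step expected from compound 3 to compound 4 is therefore a step that the limit leaves unreadable from compound 3 to compound 4, within the scatter. The estimated value for compound 4 in this assay is 30000 nM, ranging from 15000 nM to 80000 nM, most likely again reported as a limit.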

Compound 4, half-maximal effective concentration: > 26000 nM
Compound 4 ended at the assay's limit; the forecaster's own chance of this, stated with the estimate: 85%; the middle value lies beyond the limit too.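

Compound 3 and compound 4 both end at a limit in this assay, so the step from the pyridin-3-yl group to the 2-fluoro-5-methoxyphenyl group cannot be read. The compounds shown leave open whether any change of aryl group or chain end alters the value in this assay.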